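Swapping a nitrile for chlorine on the sulfonyl aryl ring

The compounds below may be only part of what the source reports. "The series", "measured", "known", "first", "only" and "open" are said of these compounds alone.

Measured so far:
compound 1, `Cc1ccc(S(=O)(=O)c2cnc3ccc(Cl)cc3c2N2CCC(C)CC2)cc1C`, 84%
compound 2, `COc1ccc(S(=O)(=O)c2cnc3ccc(Cl)cc3c2N2CCC(C)CC2)cc1OC`, 61%
compound 3, `CC1CCN(c2c(S(=O)(=O)c3ccc(C#N)cc3)cnc3ccc(Cl)cc23)CC1`, 31%

These three compounds share one core and differ only in the aryl ring attached to the sulfonyl sulfur. In an assay on isolated protein for displacement of a labelled ligand from metabotropic glutamate receptor 5 (Homo sapiens), with a stated time of 60 min, tested at 1 uM (a higher number here means more inhibition at the concentration tested (going by the name of the read-out), a lower number less inhibition), compound 3 stands lowest of the three: the step of a number 53 percentage points lower from compound 1 to compound 3 (beyond the scatter) is large, and the step of a number 30 percentage points lower from compound 2 to compound 3 (beyond the scatter) is modest. The step of a number 23 percentage points lower from compound 1 to compound 2 (beyond the scatter) shows that the other two aryl rings also differ from each other.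

Compound 4, `CC1CCN(c2c(S(=O)(=O)c3ccc(Cl)cc3)cnc3ccc(Cl)cc23)CC1`, is not yet measured. It differs from compound 3 in one place: chloro in place of cyano on an aromatic carbon.

Within the data shown here, none of the measured steps is this same change, so they bear on it only indirectly. They show that the 4-cyanophenyl ring of compound 3 gives the lowest number of the three rings tried, and that moving away from it toward either other ring raised the number by a modest to large amount. Exchanging the cyano for a chloro is a move away from the 4-cyanophenyl ring, so a rise beyond the scatter is expected, though its size is uncertain. For compound 4 the expected step is a number 29 percentage points higher from compound 3 to compound 4 (beyond the scatter). The estimate for compound 4 in this assay is 60%, with a range from 35% to 85%.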

Compound 4, a percentage reported as inhibition, at one concentration (the size of the read-out at that concentration, not a potency): 92%
Estimate against measurement, compound 4: 32 percentage points below; the measured number lies above the stated range.
By their numbers in this assay, from the lowest: compound 3; then compound 2; then compounds 1 and 4 (each within the scatter of the next).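

In this assay, exchanging only the cyano for a chloro on the sulfonyl aryl ring gives a number 61 percentage points higher from compound 3 to compound 4 (beyond the scatter), so a single group at this place, para to a large group, can largely set the read-out. The 4-chlorophenyl ring also separates from the 3,4-dimethoxyphenyl ring, with a number 31 percentage points higher from compound 2 to compound 4 (beyond the scatter), whereas the comparison with the 3,4-dimethylphenyl ring gives a number 8 percentage points higher from compound 1 to compound 4 (within the scatter), so these two rings cannot be told apart in this measurement. Nothing available explains why the cyano and chloro compounds differ so widely.

The compounds shown leave open whether chloro is special at this place or whether other small groups, such as fluoro, bromo, methyl or methoxy, would give a similar number, and how a carboxylic acid or an amine there would fare. As far as these compounds go, because the read-out comes from one concentration and is not a potency, it also remains open whether compound 1 and compound 4 would still match across a full range of concentrations.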